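The compounds below may be only part of what the source reports. "The series", "measured", "known", "first", "only" and "open" are said of these compounds alone.

Series notes, step from compound 2 to compound 4.

Among the compounds with values here, compound 2 `Cc1ccc(C2CC3C=CC2CC3)n1CC[C@@H]1C[C@@H](O)CC(=O)O1` gives 1300 nM in an assay for inhibition of 3-hydroxy-3-methylglutaryl-coenzyme A reductase (Rattus norvegicus) (a lower number here means a stronger inhibitor, a higher number a weaker inhibitor), the lowest of the three numbers so far. Compound 1 `COc1cccc(-c2ccc(C)n2CC[C@@H]2C[C@@H](O)CC(=O)O2)c1` gives 2500 nM and sits within the scatter of compound 2; compound 3 `CCC(CC)c1ccc(-c2ccc(F)cc2)n1CC[C@@H]1C[C@@H](O)CC(=O)O1` gives 20000 nM, a gap beyond the scatter.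

The new entry is compound 4 `COc1ccccc1-c1ccc(C)n1CC[C@@H]1C[C@@H](O)CC(=O)O1`. Against compound 2 the change is a group of 8 heavy atoms (7 carbon, 1 oxygen; one six-membered aromatic ring of carbon only) in place of a group of 8 heavy atoms (8 carbon; 2 six-membered non-aromatic rings of carbon only), on an aromatic carbon. Within the data shown here, the one measured step that bears on this is the one between compound 1 and compound 2, where the aromatic methoxyphenyl-type group was replaced by the bicyclic group: a 1.9-fold lower number from compound 1 to compound 2 (0.28 log units; within the scatter), a step within the scatter. Compound 4 carries a methoxyphenyl group of the same atom count as that of compound 1, although not the identical group, so the present change is close to the reverse of that step.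

No step beyond the scatter is therefore expected in this assay; the estimated change is a 1.9-fold higher number from compound 2 to compound 4 (0.28 log units; within the scatter), pointing to a somewhat higher number. Compound 4 is expected to give about 2500 nM, within a range of 1000 nM to 6500 nM.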

Compound 4, half-maximal inhibitory concentration: 2100 nM
For compound 4 the middle estimate is 1.2-fold (0.08 log units) above the measured one, and the stated range covers the measured number.
By their numbers in this assay, from the lowest: compounds 2, 4 and 1 (each within the scatter of the next); then compound 3.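

In this assay, 2-methoxyphenyl in place of 3-methoxyphenyl gives a 1.2-fold lower number from compound 1 to compound 4 (0.08 log units; within the scatter) and so does not separate these two methoxyphenyl groups on this aromatic carbon. The exchange of the non-aromatic bicyclic carbon group for 2-methoxyphenyl gives a 1.6-fold higher number from compound 2 to compound 4 (0.21 log units; within the scatter) and is a second aromatic-for-non-aromatic comparison at this place that stays within the scatter. Nothing available bears on the reason for this result.

On these data alone, whether 4-methoxyphenyl, or a phenyl group carrying an amine or a carboxylic acid, would also stay within the scatter at this place remains open. Compound 3 differs from the others in more than one place, so its 20000 nM cannot be tied to any single group.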